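Selenium for sulfur on the chlorothiophene diacyl isothiourea

This account rests on a few compounds, and the source may have more. Where it says the series, first, only, none or still open, it means among the compounds named here.

Three compounds of this series have been run in an ADME assay on MCF-10A cells (Homo sapiens) for cytotoxicity, read by MTT assay, with a stated time of 72 h; on this read-out lower numbers stand for stronger inhibition of growth and higher numbers for weaker inhibition of growth. Compound 1 `CS/C(=N\C(=O)c1sccc1Cl)NC(=O)c1sccc1Cl` gives 90 nM and stands at the lowest number of the three, with both other compounds beyond the scatter. Compound 2 `CS/C(=N\C(=O)c1ccco1)NC(=O)c1ccco1` gives 8220 nM in this assay, and compound 3 `C[Se]/C(=N\C(=O)c1cccs1)NC(=O)c1cccs1` gives 9260 nM. Compound 2 and compound 3 sit close to each other and far from compound 1. Among the compounds with values here, no two of the measured compounds differ in only one place, so no single-point step is available; compound 3 differs from compound 1 both at the chalcogen and at the substituent of the ring.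

The next compound, compound 4 `C[Se]/C(=N\C(=O)c1sccc1Cl)NC(=O)c1sccc1Cl`, takes the step from compound 1 in one place: a group of 2 heavy atoms (1 carbon, 1 selenium; no ring) in place of a group of 2 heavy atoms (1 carbon, 1 sulfur; no ring), on a carbon with a double bond to nitrogen. Nothing measured isolates this exchange. Within the data shown here, compound 3, the one selenium-bearing compound, carries a different aromatic part, so its number does not transfer. The expectation for compound 4 is a small step in this assay from compound 1, a 2.2-fold higher number from compound 1 to compound 4 (0.35 log units; beyond the scatter), most likely toward a higher number and possibly within the scatter. Compound 4 is therefore estimated at 200 nM, with a range from 40 nM to 1500 nM.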

Compound 4, concentration for 50% growth inhibition: 3160 nM
For compound 4 the middle estimate is 16-fold (1.20 log units) below the measured one, outside the stated range (above it).
By their numbers in this assay, from the lowest: compound 1; then compound 4; then compounds 2 and 3 (each within the scatter of the next).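

In this assay, putting the selenium-bearing group in place of methylsulfanyl, on a carbon with a double bond to nitrogen, gives a 35-fold higher number from compound 1 to compound 4 (1.55 log units; beyond the scatter), a large step and the first in this series to isolate a change in one place. With the rest of compound 1 held fixed, this single exchange accounts for a substantial loss of growth inhibition, so this position is sensitive to the exchange and the low number of compound 1 is tied to methylsulfanyl within this pair. Nothing available explains why the step is so large.

Still open, as far as these compounds go, is how a methoxy group, an amine or a longer chain such as ethylsulfanyl would behave on the same carbon, and so whether the low number of compound 1 is particular to methylsulfanyl or is shared by other groups there. The step also rests on a single pair, which leaves open whether the same exchange would have a step of similar size on the shared core when it carries a different aromatic part.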